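This account rests on a few compounds, and the source may have more. Where it says the series, first, only, none or still open, it means among the compounds named here.

Compound 2 `CCN(CC)S(=O)(=O)c1ccc(S(=O)(=O)N2CCC[C@@H](C(=O)N3CCS(=O)(=O)CC3)C2)cc1` gives 900 nM in a functional assay on MIA PaCa-2 cells (Homo sapiens) for inhibition, read by MTT assay, with a stated time of 7 days; on this read-out lower numbers stand for stronger inhibition and higher numbers for weaker inhibition. Among the three numbers in hand it is the second highest. Compound 3 `CCN(CC)S(=O)(=O)c1ccc(S(=O)(=O)N2CCC[C@@H](C(=O)N[C@H]3CC[C@@H](OC)CC3)C2)cc1` gives 960 nM in this assay. Compound 1 `O=C([C@@H]1CCCN(S(=O)(=O)c2ccc(S(=O)(=O)C3CCC3)cc2)C1)N1CCC(F)(F)CC1` differs from compound 2 in several places; in this assay compound 1 gives 9 nM. Among the measured compounds shown here, the only single-point step recorded is a 1.1-fold higher number from compound 2 to compound 3 (0.03 log units; within the scatter), an exchange of the amide partner on the carbonyl carbon. Compound 4 `CCN(CC)S(=O)(=O)c1ccc(S(=O)(=O)N2CCC[C@@H](C(=O)N3CCC(COC)CC3)C2)cc1` differs from compound 2 by 4-(methoxymethyl)piperidin-1-yl in place of 1,1-dioxothiomorpholin-4-yl on a carbonyl carbon, another exchange of the amide partner at the same carbonyl carbon. For the measured compounds named here, that one earlier step at this position stayed within the scatter, and no other step informs the change. No shift beyond the scatter is therefore expected, no change at the digits printed from compound 2 to compound 4 (within the scatter). Compound 4 is estimated at 900 nM, with a range of 350 nM to 2300 nM.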

Compound 4, half-maximal inhibitory concentration: 250 nM
The estimate for compound 4 lay 3.6-fold (0.56 log units) above the measured number; the whole stated range lies above it.
By their numbers in this assay, from the lowest: compound 1; then compound 4; then compounds 2 and 3 (each within the scatter of the next).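

The amide partner on the carbonyl carbon does move the number in this assay, which the exchange alone in a 1.1-fold higher number from compound 2 to compound 3 (0.03 log units; within the scatter) did not show. With 4-(methoxymethyl)piperidin-1-yl there is a 3.6-fold lower number from compound 2 to compound 4 (0.56 log units; beyond the scatter), and the same partner gives a 3.8-fold lower number from compound 3 to compound 4 (0.58 log units; beyond the scatter), so it stands apart from both other partners. No measurement shown accounts for this shift.

Open, going by these compounds, is what an unsubstituted piperidin-1-yl or a 4-(hydroxymethyl)piperidin-1-yl partner would give on the same core. Also open, on these data alone, is whether 4-(methoxymethyl)piperidin-1-yl would shift the number on the core of compound 1.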